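The source may report more compounds than this note shows. Statements on the series, on what has been measured and on what is new or still open speak of the compounds shown alone.

Measured compounds:
compound 1, `CC(C)[C@H](NC(=O)c1cc(Cl)ccc1O)C(=O)Nc1ccc(Cl)cc1`: > 10000 nM
compound 2, `C[C@H](NC(=O)c1ccc(Cl)cc1O)C(=O)Nc1ccc(C(F)(F)F)cc1`: > 12500 nM
compound 3, `CC(C)[C@H](NC(=O)c1cc(Cl)ccc1O)C(=O)Nc1ccc(C(F)(F)F)cc1`: 7300 nM

In a functional assay on MCF7 cells (Homo sapiens) for cytotoxicity, with a stated time of 72 h (a higher number here means a weaker inhibitor, a lower number a stronger inhibitor), compound 3 gives 7300 nM. Compound 1 in this assay gives > 10000 nM, which is a limit of the assay and not a number. Compound 2 likewise gives only a limit in this assay, > 12500 nM. The change from compound 3 to compound 1 is chloro in place of trifluoromethyl on an aromatic carbon, and it made an at least 1.3-fold higher number from compound 3 to compound 1 (0.13 log units; that floor lies within the scatter); that step is only a floor because compound 1 sits at the limit of > 10000 nM in this assay, at which 1 of the 3 values shown sits.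

Compound 4, `C[C@H](NC(=O)c1ccc(Cl)cc1O)C(=O)Nc1ccc(Cl)cc1`, has not yet been measured in this assay. It arises from compound 2 by the same change, (chloro in place of trifluoromethyl on an aromatic carbon). The difference between the core of compound 2 and the core of compound 3 is not broken down here. Compound 2 rests at the limit of > 12500 nM in this assay, at which 1 of the 3 values shown sits, so only a floor is known for the starting point of the new step.

The expected step is a step that the limit leaves unreadable from compound 2 to compound 4, resting on an at least 1.3-fold higher number from compound 3 to compound 1 (0.13 log units; that floor lies within the scatter) and on the limit seen for compound 2. Compound 4 is estimated at 20000 nM, within 8000 nM to 60000 nM, and is expected most likely to be reported as a limit again.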

Compound 4, half-maximal inhibitory concentration: > 10000 nM
Compound 4 was reported as a limit (the forecaster's own chance of this, stated with the estimate: 85%); the middle value does not contradict the limit.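

In this assay, going by these compounds alone, compound 2 and compound 4 are both reported only as limits of the assay and not as numbers, and no step between them can be read. The compounds shown leave open whether chloro in place of trifluoromethyl on an aromatic carbon changes the read-out at all on the core of compound 2.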